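This account rests on a few compounds, and the source may have more. Where it says the series, first, only, none or still open, it means among the compounds named here.

Compound 1 `CCNC(=S)Nc1cccc(C(F)(F)F)c1` was examined in an ADME assay on BHK cells (Mesocricetus auratus) for cytotoxicity, read by MTT assay, with a stated time of 96 h; a lower number here means that less compound is tolerated, a higher number that more compound is tolerated. In this assay compound 1 gives > 100000 nM, which is a limit of the assay rather than a number. Compound 3 `O=C(NC(=S)Nc1cccc(C(F)(F)F)c1)c1ccccc1` also reaches only a limit in this assay, at > 100000 nM. Compound 2 `CCCCc1ccc(NC(=S)Nc2cccc(C(F)(F)F)c2)c(C)c1` gives a measured number in this assay, 9000 nM. Compound 1 therefore stands at the limit of > 100000 nM in this assay, at which 2 of the 3 values shown sit, and no number separates it from compound 3. Within the data shown here, no two of the measured compounds differ in a single place, so no measured step is available to guide the next one. Compound 4 `CSCCCNC(=S)Nc1cccc(C(F)(F)F)c1` is the unmeasured compound; it differs from compound 1 by (methylsulfanyl)methyl in place of hydrogen on a saturated chain carbon, two bonds along the chain from an amide-type nitrogen. Since compound 1 stands at the limit of > 100000 nM in this assay, at which 2 of the 3 values shown sit, compound 4 is expected to give either a limit again or a number close to it. The step this estimate means, a number no higher from compound 1 to compound 4 (the limit leaves the size open), is expected to be no larger than the scatter. Compound 4 is estimated at 100000 nM, with a range from 30000 nM to 300000 nM.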

Compound 4, half-maximal cytotoxic concentration: > 100000 nM
Compound 4: a limit, no number; the forecaster's own chance of this, stated with the estimate: 60%; the middle value sits exactly at the limit.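

In this assay compound 1 and compound 4 both reach only a limit, not a number, so no step can be read between them: the limit of > 100000 nM in this assay, at which 3 of the 4 values shown sit. The compounds shown leave open whether (methylsulfanyl)methyl in place of hydrogen shifts the tolerated concentration at all, and by how much.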